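From 4-iodophenyl to 2-bromo-5-fluorophenyl on a shared core

The compounds below may be only part of what the source reports. "The series", "measured", "known", "first", "only" and "open" are said of these compounds alone.

Measured in a functional assay on HepG2 cells (Homo sapiens) for inhibition, read by MTT assay; on this read-out higher numbers stand for weaker inhibition and lower numbers for stronger inhibition:
- compound 1 `COc1cc2ncnc(Nc3ccc(NC(=O)c4ccccc4C)cc3)c2cc1OC`: 15000 nM
- compound 2 `COc1cc2ncnc(Nc3ccc(NC(=O)c4ccc(Br)cc4)cc3)c2cc1OC`: 35000 nM
- compound 3 `COc1cc2ncnc(Nc3ccc(NC(=O)c4ccc(I)cc4)cc3)c2cc1OC`: 40000 nM

Compound 3 stands level with compound 2 at the high end of these numbers, and both lie beyond the scatter from compound 1. The next compound, compound 4 `COc1cc2ncnc(Nc3ccc(NC(=O)c4cc(F)ccc4Br)cc3)c2cc1OC`, replaces one aryl group with another: 2-bromo-5-fluorophenyl in place of 4-iodophenyl on a carbonyl carbon. For the measured compounds named here, three measured steps bear on this change. Swapping iodo for bromo made no real difference, with a 1.1-fold higher number from compound 2 to compound 3 (0.06 log units; within the scatter). The two steps that changed the group on the carbonyl carbon were modest, at a 2.3-fold higher number from compound 1 to compound 2 (0.37 log units; beyond the scatter) and a 2.7-fold higher number from compound 1 to compound 3 (0.43 log units; beyond the scatter). Going by the values given here, compound 4 matches none of the measured groups, so these steps offer only a rough guide to size. A modest move toward the value of compound 1 is therefore expected in this assay, and it may not clear the scatter. The expected change is a 1.8-fold lower number from compound 3 to compound 4 (0.26 log units; within the scatter). For compound 4 the estimated value is 22000 nM, with an expected range of 10000 nM to 45000 nM.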

Compound 4, half-maximal inhibitory concentration: 22000 nM
Estimate against measurement, compound 4: no gap at the digits printed; the range from low to high includes it.
By their numbers in this assay, from the lowest: compounds 1, 4, 2 and 3 (each within the scatter of the next, the first and the last beyond it).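

In this assay the 2-bromo-5-fluorophenyl group on the carbonyl carbon gives a 1.8-fold lower number from compound 3 to compound 4 (0.26 log units; within the scatter) and a 1.6-fold lower number from compound 2 to compound 4 (0.20 log units; within the scatter) and also a 1.5-fold higher number from compound 1 to compound 4 (0.17 log units; within the scatter) as its steps to the other three compounds, and none of these leaves the scatter. The earlier compounds shown here showed compound 1 apart from compounds 2 and 3, and compound 4 now fills that gap, although compound 1 and compound 3 remain beyond the scatter of each other. Across these four aryl groups, this position has so far given only modest differences.

From the compounds shown here alone, whether an amine or a carboxylic acid on this aryl ring, or a longer chain in its place, would give a larger step remains open. Nothing available accounts for any of these differences.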